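From Methylamino to Anilino in a Series of Limits

The source may hold more compounds than are shown below. What is called first, only, known or untested is meant among the compounds shown, and "the series" means these compounds.

Compound 2 `CNc1nc(NC)nc(NC2(C#N)CCCCC2)n1` has been tested in an in vitro assay on Sf21 cells for inhibition of high affinity 3',5'-cyclic-AMP phosphodiesterase 7A (Homo sapiens); a lower number here means a stronger inhibitor, a higher number a weaker inhibitor. In this assay compound 2 gives > 1000 nM, which is a limit of the assay rather than a number. The two compounds measured alongside it are known only as limits as well. In this assay compound 1 `CNc1nc(NC2(C#N)CCCCC2)nc(-n2cnc(C)n2)n1` gives > 5000 nM, a limit. In this assay compound 3 `CNc1nc(NC2(C#N)CCCCC2)nc(N(C)C)n1` gives > 5000 nM, again a limit. Compound 2 thus stands at the limit of > 1000 nM in this assay, at which 1 of the 3 values shown sits, while the other two sit at the limit of > 5000 nM in this assay, at which 2 of the 3 values shown sit, and the limits do not place compound 2 relative to them.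

Compound 4 `CNc1nc(Nc2ccccc2)nc(NC2(C#N)CCCCC2)n1` differs from compound 2 by phenyl in place of methyl on a nitrogen on an aromatic ring, the same difference read one bond further out being methylamino to anilino. Within the data shown here, no measured step covers this exchange. Among the measured compounds shown here, the steps on record, a step that the two limits leave unreadable from compound 1 to compound 2, a step that the two limits leave unreadable from compound 1 to compound 3 and a step that the two limits leave unreadable from compound 2 to compound 3, are all left unreadable by the limits, so none gives a size to carry over, and the exchange of methyl for phenyl on a nitrogen on an aromatic ring has no precedent in this set. With compound 2 known only as a limit, no direction can be read from the series either. Compound 4 is therefore estimated at 2000 nM in this assay, within a wide range from 300 nM to 10000 nM. For the measured compounds named here, the step this estimate means, a step that the limit leaves unreadable from compound 2 to compound 4, is expected to be small and rests on no measured step.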

Compound 4, half-maximal inhibitory concentration: > 5000 nM
Compound 4: no number, only a limit; the forecaster's own chance of this, stated with the estimate: 55%; middle value at least 2.5-fold (0.39 log units) from the limit.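

In this assay compound 4 gives > 5000 nM, a limit of the assay and not a number. Among these compounds, compound 1, compound 2 and compound 3 are also known only as limits, so no step joining any of them to compound 4 can be read. The compounds shown leave open whether the methylamino, dimethylamino, anilino and 3-methyl-1H-1,2,4-triazol-1-yl groups differ at all in this assay.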